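Thienopyrimidine ketones: thiazolyl for chlorothienyl at the carbonyl

A few compounds are considered here, and "the series" means these few. Any claim that something is new, unique, unknown or untested is made for them only; others in the source may bear on it.

Measured so far:
compound 1 `Cc1ccc(C(=O)c2nc(NCc3ccccc3)nc3ccsc23)s1` — 5580 nM
compound 2 `O=C(c1ccc(Cl)s1)c1nc(NCc2cccnc2)nc2ccsc12` — 487 nM

Both compounds were run in a functional assay on CHO-K1 cells for antagonist activity at adenosine receptor A2b (Homo sapiens), read by FLIPR and calcium flux; a lower number here means a stronger inhibitor, a higher number a weaker inhibitor. Among the compounds with values here, compound 2 holds the lowest of the two numbers; the only neighbour, compound 1, gives 5580 nM, a gap beyond the scatter. Within the data shown here, compound 1 and compound 2 differ in more than one place, so no single step can be drawn between them; their two values are all that can be said.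

Compound 3 `O=C(c1cncs1)c1nc(NCc2cccnc2)nc2ccsc12` has not been measured. It differs from compound 2 in one place: 1,3-thiazol-5-yl in place of 5-chlorothiophen-2-yl on a carbonyl carbon. Among the measured compounds shown here, no comparable step is available among the measured compounds, so the direction of this change rests on no data here. In this assay a small upward step, close to the scatter, is expected for compound 3, with a wide margin on either side. For compound 3 the estimate is 900 nM, in the range 300 nM to 3000 nM, meaning an expected step of a 1.8-fold higher number from compound 2 to compound 3 (0.27 log units; within the scatter).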

Compound 3, half-maximal inhibitory concentration: 148 nM
For compound 3 the middle estimate is 6.1-fold (0.78 log units) above the measured one; the whole stated range lies above it.
By their numbers in this assay, from the lowest: compound 3; then compound 2; then compound 1.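

In this assay, within the data shown here, the only single-place step falls on the carbonyl carbon: 1,3-thiazol-5-yl in place of 5-chlorothiophen-2-yl gives a 3.3-fold lower number from compound 2 to compound 3 (0.52 log units; beyond the scatter). The number at this position therefore depends on the ring carried there, and the chlorine-bearing thiophene is not required, since the thiazole with its second ring hetero atom gives the lower value. No measurement at hand bears on why the number falls.

The step changes the ring nitrogen and the chlorine together, so the compounds shown leave open which of the two accounts for it; an unsubstituted thiophen-2-yl or a 1,3-thiazol-2-yl on the same carbonyl would begin to separate them. Going by these compounds, whether the step holds with a benzyl amine in place of the pyridinylmethyl amine also stays open.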